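Nitro substitution on the aryl ring: Vero cytotoxicity notes

The source may hold more compounds than are shown below. What is called first, only, known or untested is meant among the compounds shown, and "the series" means these compounds.

Measured compounds in the series:
compound 1, `C=CCN(CC=C)C(=S)N/N=C(/C)c1ccccc1`: 229000 nM
compound 2, `C=CCN(CC=C)C(=S)N/N=C(/C)c1ccc([N+](=O)[O-])cc1`: < 197000 nM
compound 3, `C/C(=N/NC(=S)N(Cc1ccccc1)Cc1ccccc1)c1ccccc1`: 167000 nM

All three were run in an ADME assay on Vero cells (Chlorocebus sabaeus) for cytotoxicity, read by MTT assay, with a stated time of 72 h; on this read-out higher numbers stand for lower toxicity in this test and lower numbers for higher toxicity in this test. Compound 1 gives 229000 nM. For compound 2 the reported value < 197000 nM is a limit of the assay and not a number; it is the limit of < 197000 nM in this assay, at which 1 of the 3 values shown sits. Compound 3 gives 167000 nM; set against compound 1, the two numbers lie within the usual scatter of this read-out, so no order between them is drawn.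

The change from compound 1 to compound 2 is nitro in place of hydrogen on an aromatic carbon. It made an at least 1.1-fold lower number from compound 1 to compound 2 (0.06 log units; that floor lies within the scatter), and since one end is a limit, the true size of that step is not fixed. How the cores of compound 1 and compound 3 differ is not broken down here.

Compound 4, `C/C(=N/NC(=S)N(Cc1ccccc1)Cc1ccccc1)c1ccc([N+](=O)[O-])cc1`, is not yet measured. It carries the same change relative to compound 3: nitro in place of hydrogen on an aromatic carbon. Both occurrences put the nitro on an aromatic carbon para to a large group, so the change is counted as the same one; among the compounds shown it occurs twice.

The step from compound 3 to compound 4 is expected to be a 1.2-fold lower number from compound 3 to compound 4 (0.08 log units; within the scatter), resting on the measured step of an at least 1.1-fold lower number from compound 1 to compound 2 (0.06 log units; that floor lies within the scatter), which lies within the scatter. For compound 4 the estimated value in this assay is 140000 nM. For compound 4 the expected range runs from 80000 nM to 250000 nM.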

Compound 4, half-maximal cytotoxic concentration: < 150000 nM
Compound 4 ended at the assay's limit (the forecaster's own chance of this, stated with the estimate: 30%); the middle value is on the limit's open side.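

In this assay compound 4 is reported as < 150000 nM, which is a limit of the assay and not a number. Phenyl to 4-nitrophenyl on the core of compound 3 gives an at least 1.1-fold lower number from compound 3 to compound 4 (0.04 log units; that floor lies within the scatter), so this core, like the core of compound 1, supplies only a floor for the change and not a measured size. The readings from the two cores do not conflict, but they do not show that the change carries from one core to the other with a fixed size, and any real difference between the cores stays unresolved: the same change on two cores in this assay, an at least 1.1-fold lower number (0.06 log units; that floor lies within the scatter) from compound 1 to compound 2 and an at least 1.1-fold lower number (0.04 log units; that floor lies within the scatter) from compound 3 to compound 4; the limit leaves it open whether they differ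

The compounds shown leave open how either core responds to a group other than nitro on an aromatic carbon para to a large group, such as an amine or a carboxylic acid. They also leave open whether such a group would give a number rather than a limit in this assay, which would allow the step to be sized on each core and the two cores to be compared directly.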